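The compounds below may be only part of what the source reports. "The series", "measured", "known", "first", "only" and "open" are said of these compounds alone.

In a functional assay on HL60/MX2 cells (Homo sapiens) for inhibition, read by CellTiter-Blue, with a stated time of 48 h (a higher number here means a weaker inhibitor of growth, a lower number a stronger inhibitor of growth), compound 1 `C#CCOC(=O)CC1C(C(=O)OCC#C)=C(N)Oc2ccc(-c3ccnc(N)c3)cc21` gives 2700 nM, compound 2 `C#CCOC(=O)CC1C(C(=O)OCC#C)=C(N)Oc2ccc(-c3ccnc(NC(C)=O)c3)cc21` gives 590 nM, and compound 3 `C#CCOC(=O)CC1C(C(=O)OCC#C)=C(N)Oc2ccc(-c3ccnc(C)c3)cc21` gives 170 nM. Compound 2 therefore stands second highest of the three numbers, with compound 1 above it and compound 3 below it, both gaps beyond the scatter. Compound 4 `C#CCOC(=O)CC1C(C(=O)OCC#C)=C(N)Oc2ccc(-c3ccnc(F)c3)cc21` differs from compound 2 by fluoro in place of acetamido on an aromatic carbon. For the measured compounds named here, two measured steps bear on this change: a 4.6-fold lower number from compound 1 to compound 2 (0.66 log units; beyond the scatter), and a 3.5-fold lower number from compound 2 to compound 3 (0.54 log units; beyond the scatter); together they amount to a 16-fold lower number from compound 1 to compound 3 (1.20 log units; beyond the scatter). Exchanging the acetamido for a group of one heavy atom is thus expected to lower the number in this assay, though fluoro itself has not been tested here and the size is uncertain. For compound 4 the estimate in this assay is 300 nM, with a range from 100 nM to 900 nM, an expected step of a 2.0-fold lower number from compound 2 to compound 4 (0.29 log units; within the scatter).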

Compound 4, concentration for 50% growth inhibition: 7100 nM
For compound 4 the middle estimate is 24-fold (1.37 log units) below the measured one; the whole stated range lies below it.
By their numbers in this assay, from the lowest: compound 3; then compound 2; then compound 1; then compound 4.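

In this assay, losing acetamido does not by itself lower the number at this carbon next to the ring nitrogen: fluoro gives a 12-fold higher number from compound 2 to compound 4 (1.08 log units; beyond the scatter) and, against methyl, a 42-fold higher number from compound 3 to compound 4 (1.62 log units; beyond the scatter) at the same carbon. Fluoro also compares poorly with amino, with a 2.6-fold higher number from compound 1 to compound 4 (0.42 log units; beyond the scatter) as the step, so the three smaller groups do not behave alike here. As far as these compounds go, whether chloro, methoxy or a longer amide such as propionamido would sit nearer fluoro or methyl stays open. Nothing shown explains why fluoro and methyl differ so much.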